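Swapping the aryl arm for a small amide on a nucleoside core

The compounds below may be only part of what the source reports. "The series", "measured", "known", "first", "only" and "open" are said of these compounds alone.

Measured compounds:
- Compound 1, `COc1ccc(Cn2c(=O)n(C3OC(CO)[C@@H](O)[C@H]3O)c3nc(N)nc(O)c32)cc1`: 44%
- Compound 2, `Cn1c(=O)n(C2OC(CI)[C@@H](O)[C@H]2O)c2nc(N)nc(O)c21`: 32%

Both compounds were tested in a functional assay on the whole organism (B cells) with Mus musculus as the target; on this read-out lower numbers stand for smaller maximal responses and higher numbers for larger maximal responses. Compound 1 gives 44%, the higher of the two numbers. Compound 2 gives 32%, a value that lies below compound 1 by more than the usual scatter of such measurements. The two compounds differ in more than one place, so their pair of values says only that much and nothing about any single change.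

Compound 3, `NC(=O)Cn1c(=O)n(C2OC(CO)[C@@H](O)[C@H]2O)c2nc(N)nc(O)c21`, has not yet been measured. It shares the core of compound 1 and differs from it in one place: carbamoyl in place of 4-methoxyphenyl on a saturated chain carbon bound to an aromatic nitrogen. A large aromatic group is thus exchanged for a small group that carries both a hydrogen-bond donor and an acceptor.

For the measured compounds named here, no measured pair isolates this change, so the expectation rests on loose grounds. The step is expected to be a number 8 percentage points lower from compound 1 to compound 3 (within the scatter), a modest change. Compound 3 is estimated at 36%, with a range from 15% to 58%.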

Compound 3, largest response reached (reported as maximal response), in percent of the reference or control that the assay uses: 32%
Compound 3: the middle estimate sits 4 percentage points above what was measured; the range from low to high includes it.
By their numbers in this assay, from the lowest: compounds 2 and 3 (each within the scatter of the next); then compound 1.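

In this assay, for the compounds shown here, putting carbamoyl in place of 4-methoxyphenyl on a saturated chain carbon bound to an aromatic nitrogen gives a number 12 percentage points lower from compound 1 to compound 3 (beyond the scatter) and is the only change in this set that can be read in one place. It shows that the group at this position matters for the size of the maximal response, since nothing else differs between these two compounds, while compound 3 still gives 32% with no ring on this chain at all. Nothing measured here explains why the value moves with this swap.

The swap removes a ring and the methoxy group, shrinks the arm from 8 heavy atoms to 3, and brings in a hydrogen-bond donor all at once, so a single step cannot say which of these differences accounts for the result. A plain phenyl or a simple methyl at this position would help separate the part played by the ring from that of the methoxy group, and a carboxylic acid or an amine would show how much depends on the amide itself.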